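The source may hold more compounds than are shown below. What is called first, only, known or untested is meant among the compounds shown, and "the series" means these compounds.

Among the measured compounds shown here, in a functional assay on HCT-116 cells (Homo sapiens) for cytotoxicity, read by fluorescence, with a stated time of 72 h (on this read-out higher numbers stand for weaker inhibition and lower numbers for stronger inhibition), compound 2 `CC(C)c1n[nH]c2c(NCc3ccc(-c4ccccn4)cc3)nc(N3CCNCC3)nc12` gives 88 nM, the lowest of the two numbers so far, while compound 1 `CSc1nc(NCc2ccc(-c3ccccn3)cc2)c2[nH]nc(C(C)C)c2n1` gives 2800 nM. Compound 3 `CC(C)c1n[nH]c2c(NCc3ccc(-c4ccccn4)cc3)nc(NCCN(C)C)nc12` differs from compound 2 in one place: (2-(dimethylamino)ethyl)amino in place of piperazin-1-yl on an aromatic carbon, with (2-(dimethylamino)ethyl)amino in place of piperazin-1-yl on an aromatic carbon. For the measured compounds named here, one measured step bears on this carbon: a 32-fold lower number from compound 1 to compound 2 (1.50 log units; beyond the scatter), a large step beyond the scatter, with piperazin-1-yl in place of methylsulfanyl. No open-chain amine has yet been measured there, so the expectation is uncertain. The estimated step is a 1.5-fold higher number from compound 2 to compound 3 (0.17 log units; within the scatter), not expected to exceed the scatter in this assay. Compound 3 is estimated at 130 nM, within a range of 35 nM to 450 nM.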

Compound 3, half-maximal inhibitory concentration: 390 nM
Compound 3: middle estimate off by 3.0-fold (0.48 log units), on the low side; low and high end bracket the measured number.
By their numbers in this assay, from the lowest: compound 2; then compound 3; then compound 1.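

In this assay, the amine at this carbon cannot be exchanged freely: (2-(dimethylamino)ethyl)amino has the same counts of heavy atoms, donors and acceptors as piperazin-1-yl but no ring, and the change gives a 4.4-fold higher number from compound 2 to compound 3 (0.65 log units; beyond the scatter). Even so, the open-chain amine still keeps a clear advantage over methylsulfanyl, with a 7.2-fold lower number from compound 1 to compound 3 (0.86 log units; beyond the scatter). Nothing available explains why the ring and the chain differ. Going by these compounds, it remains open whether a morpholin-4-yl ring, a 4-methylpiperazin-1-yl group or a longer chain ending in an amine would match or better compound 2.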